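The source may report more compounds than this note shows. Statements on the series, on what has been measured and on what is new or still open speak of the compounds shown alone.

Working notes on this series, which is followed in a functional assay on HUVEC cells (Homo sapiens) for inhibition, read by ELISA; on this read-out lower numbers stand for stronger inhibition and higher numbers for weaker inhibition. Compound 2 `CCc1nnc([S+]([O-])Cc2ncc(C)c(OC)c2C)o1` gives 12000 nM in this assay, the highest of the two numbers recorded so far. Compound 1 `[O-][S+](Cc1ccccc1)c1nnc(-c2ccncc2)o1` gives 4000 nM in this assay, a lower number than compound 2 and beyond the scatter. Compound 3 `COc1c(C)cnc(C[S+]([O-])c2nnc(-c3cccc(F)c3)o2)c1C` is not yet measured in this assay. It is formed from compound 2 by one change: 3-fluorophenyl in place of ethyl on an aromatic carbon. In this assay compound 3 is expected to land at a lower number than compound 2, a step of a 4.8-fold lower number from compound 2 to compound 3 (0.68 log units; beyond the scatter) beyond the scatter. The estimate for compound 3 is 2500 nM, with a range from 600 nM to 10000 nM.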

Compound 3, half-maximal inhibitory concentration: 15000 nM
Compound 3: the middle estimate sits 6.0-fold (0.78 log units) below what was measured; measured number outside the range, above it.
By their numbers in this assay, from the lowest: compound 1; then compounds 2 and 3 (each within the scatter of the next).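

At this position, the aromatic carbon next to the ring nitrogen and next to the ring oxygen, 3-fluorophenyl in place of ethyl gives a 1.3-fold higher number from compound 2 to compound 3 (0.10 log units; within the scatter) in this assay and so leaves the read-out within the scatter. The two groups differ in size and in the added aromatic ring, yet the numbers do not separate. No available evidence accounts for this result.

Open, from the compounds shown here alone, is whether an amine, a carboxylic acid or a longer chain here would separate from ethyl. Also open, going by these compounds, is how plain phenyl would compare with 3-fluorophenyl.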